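This account rests on a few compounds, and the source may have more. Where it says the series, first, only, none or still open, it means among the compounds named here.

Compound 1 `CN(C)C(=O)/C=C/c1ccc2noc(-c3ccccc3)c2c1` carries a 2-(dimethylcarbamoyl)ethenyl group on its core. In an assay for inhibition of inositol hexakisphosphate kinase 3 (Homo sapiens), read by colorimetric assay, coupled enzyme assay and malachite green, with a stated time of 120 min, in the presence of a further agent that is not named here (on this read-out lower numbers stand for stronger inhibition and higher numbers for weaker inhibition), compound 1 gives only a limit, > 100000 nM, and no number; this is the limit (the limit of > 100000 nM in this assay, at which 1 of the 3 values shown sits). Two acids serve as a point of reference. Compound 2 `O=C(O)/C=C/c1ccc2noc(-c3ccc(Oc4ccccc4)cc3)c2c1` gives 760 nM in this assay, and compound 3 `O=C(O)/C=C/c1ccc2noc(-c3ccc(-c4ccccc4)cc3)c2c1` gives 200 nM. Going by the values given here, the one measured step, a 3.8-fold lower number from compound 2 to compound 3 (0.58 log units; beyond the scatter), concerns the far end of the molecule and not the side chain on the core, so it says little about the change considered here.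

Compound 4 `CNC(=O)c1ccc2noc(-c3ccccc3)c2c1` arises from compound 1 by the change (methylcarbamoyl in place of 2-(dimethylcarbamoyl)ethenyl on an aromatic carbon). Among the compounds with values here, no measured pair reports this change, and compound 1 itself sits at a limit, so the starting point is not a number. Since compound 1 stands at > 100000 nM, the step of an at least 1.2-fold lower number from compound 1 to compound 4 (0.09 log units; that floor lies within the scatter) that the estimate means cannot be pinned down beyond the expectation that compound 4 most likely stays weak. Compound 4 is expected to give about 80000 nM in this assay, within a range from 15000 nM to 300000 nM, with a fair chance that only a limit is reported again.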

Compound 4, half-maximal inhibitory concentration: 6830 nM
For compound 4 the middle estimate is 12-fold (1.07 log units) above the measured one; the measured number lies below the stated range.
By their numbers in this assay, from the lowest: compound 3; then compound 2; then compound 4. At a limit, above all of these: compound 1.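

The change of 2-(dimethylcarbamoyl)ethenyl to methylcarbamoyl on this aromatic carbon gives an at least 14-fold lower number from compound 1 to compound 4 (1.16 log units; beyond the scatter) in this assay, and it is the only step shown that concerns the side chain on the core rather than the far end of the molecule. It shows that this position responds strongly to the group it carries, and that compound 4 gives a true number, 6830 nM, with no carboxylic acid and no net charge in the entering group. Compound 1 stands at a limit, so the size of this step is a floor and not an exact figure: the limit of > 100000 nM in this assay, at which 1 of the 4 values shown sits.

The step changes several things at once, since the entering group is shorter, loses the carbon-carbon double bond of the chain and brings the amide hydrogen, and the compounds shown do not tell these apart. Also open, on these data alone, is how a dimethylcarbamoyl group or a carboxylic acid set directly on this aromatic carbon would read, and whether methylcarbamoyl would behave the same way with the phenoxy or phenyl substituent found at the far end of compound 2 and compound 3.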